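Aryl Amine Swap on a Shared Core: Compound 4

The source may hold more compounds than are shown below. What is called first, only, known or untested is meant among the compounds shown, and "the series" means these compounds.

Measured so far:
Compound 1, `CN1CCN(CCCOc2cccc3nc(Nc4ccc(Cl)c(C(F)(F)F)c4)ccc23)CC1`, gives 1210 nM.
Compound 3, `CN1CCN(CCCOc2cccc3nc(Nc4ccc(F)c(F)c4)ccc23)CC1`, gives 2420 nM.
Compound 2, `CN1CCN(CCCOc2cccc3nc(Nc4ccc(Cl)c(F)c4)ccc23)CC1`, gives "not determined" (no result reported).

The three compounds share one core and differ only in the aryl group on a nitrogen on an aromatic ring. In a functional assay on CCRF-CEM cells (Homo sapiens) for inhibition, read by sulforhodamine B assay, with a stated time of 48 h (a higher number here means a weaker inhibitor of growth, a lower number a stronger inhibitor of growth), compound 1 gives 1210 nM, and compound 3 gives 2420 nM. For the measured compounds named here, the one step between them, a 2.0-fold higher number from compound 1 to compound 3 (0.30 log units; within the scatter), is within the scatter, so these two aryl groups read as equivalent here. In this assay compound 2 gives "not determined" (no result reported), so no anchor exists for it.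

Compound 4, `CN1CCN(CCCOc2cccc3nc(Nc4cc(Cl)cc(Cl)c4)ccc23)CC1`, carries the change (3,5-dichlorophenyl in place of 4-chloro-3-fluorophenyl on a nitrogen on an aromatic ring). Going by the values given here, no measured step bears directly on this change, and since compound 2 has no value the step cannot be sized. What the data show is that both measured aryl variants fall in the same band; compound 4 is therefore expected to fall in that band as well, with a wide range. Compound 4 is estimated at 1800 nM, between 600 nM and 5500 nM.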

Compound 4, concentration for 50% growth inhibition: 1780 nM
The estimate for compound 4 lay 1.0-fold (0.00 log units) above the measured number; measured number inside the range.
By their numbers in this assay, from the lowest: compounds 1, 4 and 3 (each within the scatter of the next).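

Compound 4 adds a third substitution pattern on the phenyl group, and it does not separate from the other two in this assay: the readings are a 1.4-fold lower number from compound 3 to compound 4 (0.13 log units; within the scatter) and a 1.5-fold higher number from compound 1 to compound 4 (0.17 log units; within the scatter). Across compounds 1, 3 and 4, then, this position on the nitrogen takes 3,5-dichlorophenyl, 3,4-difluorophenyl and 4-chloro-3-(trifluoromethyl)phenyl with no change beyond the scatter, while the step from 4-chloro-3-fluorophenyl cannot be read, as compound 2 has no value. No measured evidence bears on why these aryl groups read alike.

All the aryl groups shown carry chlorine, fluorine or trifluoromethyl. On these data alone, whether an unsubstituted phenyl group, or a phenyl group bearing a methoxy group, an amine or a carboxylic acid, would stay in the same range remains open.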